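A few compounds are considered here, and "the series" means these few. Any claim that something is new, unique, unknown or untested is made for them only; others in the source may bear on it.

In an ADME assay on Vero cells (Chlorocebus sabaeus) for cytotoxicity, read by neutral red uptake, tested at 787 ug/mL (on this read-out lower numbers stand for a stronger effect and higher numbers for a weaker effect at the one concentration tested), compound 1 `O=C1CSC(c2cccc(Cl)c2)N1CCN1CCCCC1` gives 31% and stands second highest of the three numbers: compound 3 `O=C1CSC(c2cccc(F)c2)N1CCN1CCCCC1` gives 27% and compound 2 `O=C1CSC(c2ccc(O)cc2)N1CCN1CCCCC1` gives 57%. Compound 4 `O=C1CSC(c2ccc(Cl)cc2)N1CCN1CCCCC1` is unmeasured; it differs from compound 1 by 4-chlorophenyl in place of 3-chlorophenyl on a saturated ring carbon. Among the measured compounds shown here, no measured step moves a substituent around the aryl ring. The step of a number 4 percentage points lower from compound 1 to compound 3 (within the scatter) shows a halogen swap leaving the number within the scatter, whereas a number 26 percentage points higher from compound 1 to compound 2 (beyond the scatter) and a number 30 percentage points lower from compound 2 to compound 3 (beyond the scatter) involve a hydroxyl group and are modest. Keeping chloro and only shifting it, the expected step is a number 4 percentage points higher from compound 1 to compound 4 (within the scatter), inside the scatter. Compound 4 is therefore estimated at 35% in this assay, in the range 15% to 60%.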

Compound 4, a percentage reported as activity, at one concentration (the size of the read-out at that concentration, not a potency): 15%
Estimate against measurement, compound 4: 20 percentage points above, and the stated range covers the measured number.
By their numbers in this assay, from the lowest: compound 4; then compounds 3 and 1 (each within the scatter of the next); then compound 2.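

With the atoms unchanged, 4-chlorophenyl in place of 3-chlorophenyl in this assay gives a number 16 percentage points lower from compound 1 to compound 4 (beyond the scatter) and so shows that the chloro position on the aryl ring alone can move the number beyond the scatter. Among the compounds shown here, the same aryl group also gives a number 12 percentage points lower from compound 3 to compound 4 (beyond the scatter) and a number 42 percentage points lower from compound 2 to compound 4 (beyond the scatter), the latter being the largest step so far. No measurement available here explains the shift. On these data alone, whether 4-fluorophenyl would follow 4-chlorophenyl remains open. So does the outcome with an amine at that position, as in 4-aminophenyl.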